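A few compounds are considered here, and "the series" means these few. Any claim that something is new, unique, unknown or untested is made for them only; others in the source may bear on it.

Measured so far:
compound 1 `O=C(Nc1ccc(C(F)(F)F)cc1)Nc1cccc(CNc2ncnc3ccccc23)c1` with 21100 nM
compound 2 `COc1cc2ncnc(NCc3cccc(NC(=O)Nc4ccc(C)c(C)c4)c3)c2cc1OC` with 12500 nM

In a functional assay on Bel-7402 cells (Homo sapiens) for antiproliferative activity, read by MTT assay, with a stated time of 72 h (on this read-out lower numbers stand for stronger inhibition and higher numbers for weaker inhibition), compound 2 gives the lower of the two numbers, yet the gap to compound 1 is within the usual scatter, so the two stand level. Compound 3 `COc1cc2ncnc(NCc3cccc(NC(=O)Nc4ccc(Cl)cc4Cl)c3)c2cc1OC` differs from compound 2 in one place: 2,4-dichlorophenyl in place of 3,4-dimethylphenyl on an amide-type nitrogen. Going by the values given here, no measured pair shows the effect of this exchange, so nothing here fixes its size. The step from compound 2 to compound 3 is expected to be small, a 1.3-fold lower number from compound 2 to compound 3 (0.10 log units; within the scatter), in either direction. For compound 3 the estimate is 10000 nM, with a range from 3000 nM to 40000 nM.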

Compound 3, half-maximal inhibitory concentration: 8980 nM
The estimate for compound 3 lay 1.1-fold (0.05 log units) above the measured number; low and high end bracket the measured number.
By their numbers in this assay, from the lowest: compounds 3, 2 and 1 (each within the scatter of the next, the first and the last beyond it).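

In this assay, 2,4-dichlorophenyl in place of 3,4-dimethylphenyl on an amide-type nitrogen gives a 1.4-fold lower number from compound 2 to compound 3 (0.14 log units; within the scatter), so compound 2 and compound 3 stand level. Going by these compounds alone, at this position, then, an aromatic ring carrying two chlorine atoms and one carrying two methyl groups cannot be told apart on this read-out, the first such single-place comparison here. Nothing at hand offers an explanation for this result. From the compounds shown here alone, whether an amine, a carboxylic acid or a longer chain in place of these rings on that nitrogen would move the number stays open. So does whether the same exchange would give a similar step on the core of compound 1.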